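Swapping one ring on a sulfur of compound 1

The compounds below may be only part of what the source reports. "The series", "measured", "known", "first", "only" and "open" are said of these compounds alone.

In a functional assay on KYSE-70 cells for antiproliferative activity against KYSE-70 cell line (Homo sapiens), read by MTT assay, with a stated time of 72 h (a lower number here means a stronger inhibitor, a higher number a weaker inhibitor), compound 1 (`C#CCSc1nc(Sc2nncs2)c(C#N)c(-c2cc(OC)c(OC)c(OC)c2)n1`) gives 8250 nM and is the stronger of the two compounds measured. Compound 2 (`C=CC(=O)Nc1ccccc1CN(C(=O)Nc1cccc(C(F)(F)F)c1)C1CCN(C(C)CCC)CC1`), built quite differently, gives 17900 nM in the same test. Compound 3 (`C#CCSc1nc(Sc2nc(C)cs2)c(C#N)c(-c2cc(OC)c(OC)c(OC)c2)n1`) keeps the core of compound 1 but carries 4-methyl-1,3-thiazol-2-yl in place of 1,3,4-thiadiazol-2-yl on a sulfur. Within the data shown here, no measured pair shows what such a swap does in this assay here, so no clear direction can be expected. The estimated step of a 1.2-fold lower number from compound 1 to compound 3 (0.07 log units; within the scatter) is expected to stay within the usual scatter. Compound 3 is expected near 7000 nM with a range of 2800 nM to 17000 nM as a cautious allowance.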

Compound 3, half-maximal inhibitory concentration: > 20000 nM
Compound 3 was reported as a limit; the forecaster's own chance of this, stated with the estimate: 5%; middle value at least 2.8-fold (0.45 log units) from the limit.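

This first step at this position shows that the ring on the sulfur is not interchangeable in this assay: 4-methyl-1,3-thiazol-2-yl in place of 1,3,4-thiadiazol-2-yl gives an at least 2.4-fold higher number from compound 1 to compound 3 (0.38 log units; beyond the scatter) and so weakens the compound. Compound 3 gives > 20000 nM as its result, which is a limit of the assay and not a number. The step therefore rests on that limit: the limit of > 20000 nM in this assay, at which 1 of the 3 values shown sits.

Going by these compounds, the swap changes the ring and adds a methyl together, so which of the two carries the step stays open. A plain 1,3-thiazol-2-yl without the methyl, or an amine on the 1,3,4-thiadiazol-2-yl ring, would be the next question here.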